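Aryl sulfonamide variation on a cyclopropyl-oxazole core

This account rests on a few compounds, and the source may have more. Where it says the series, first, only, none or still open, it means among the compounds named here.

Measured so far:
compound 1, `O=S(=O)(Nc1ccc(F)c(Cl)c1)c1ccc(-c2cnc(C3CC3)o2)cc1`: in a functional assay on cells (leukaemia cell line, Homo sapiens) for inhibition, read by sulforhodamine B assay, with a stated time of 48 h (on this read-out lower numbers stand for higher toxicity in this test and higher numbers for lower toxicity in this test), compound 1 gives > 100000 nM, a limit of the assay.
compound 2, `O=S(=O)(Nc1ccc(Cl)c(F)c1)c1ccc(-c2cnc(C3CC3)o2)cc1`: in this assay compound 2 gives > 100000 nM, again a limit.
compound 3, `Cc1ccc(NS(=O)(=O)c2ccc(-c3cnc(C4CC4)o3)cc2)cc1C`: in this assay compound 3 gives > 100000 nM, again a limit.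

Compound 1 stands only at a limit in this assay, and it does so together with every other compound of the set, since (the limit of > 100000 nM in this assay, at which 3 of the 3 values shown sit). The three steps between measured compounds are therefore not readable: a step that the two limits leave unreadable from compound 1 to compound 2, a step that the two limits leave unreadable from compound 1 to compound 3 and a step that the two limits leave unreadable from compound 2 to compound 3. Varying the halogen pattern or exchanging the halogens for methyl groups on the sulfonamide nitrogen aryl ring has left nothing measurable in this assay within the tested range.

Compound 4, `O=S(=O)(Nc1cc(Cl)ccc1Cl)c1ccc(-c2cnc(C3CC3)o2)cc1`, is the next member. It differs from compound 1 as follows: 2,5-dichlorophenyl in place of 3-chloro-4-fluorophenyl on a sulfonamide nitrogen. The measured steps that bear on this change are all of the same kind: an aryl substituent swap on the sulfonamide nitrogen, each one unreadable because the limit of > 100000 nM in this assay, at which 3 of the 3 values shown sit, holds for all three values. No step beyond the scatter can be expected in this assay from this evidence, in either direction. Compound 4 is expected at 150000 nM, with a range from 50000 nM to 600000 nM. The step from compound 1 implied by this estimate, a step that the limit leaves unreadable from compound 1 to compound 4, is itself expected to be unreadable, most likely as a further limit.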

Compound 4, concentration lethal to 50% of the cells: > 100000 nM
Compound 4: only a limit was reported (the forecaster's own chance of this, stated with the estimate: 85%); the middle value lies beyond the limit too.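

No step can be read between compound 4 and compound 1, compound 2 or compound 3 in this assay, because all four compounds share one limit: the limit of > 100000 nM in this assay, at which 4 of the 4 values shown sit. The compounds shown leave open whether these aryl groups on the sulfonamide nitrogen differ at all, and what concentration of any of them would be lethal to the cells in this assay.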